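The source may hold more compounds than are shown below. What is called first, only, known or untested is meant among the compounds shown, and "the series" means these compounds.

Compound 1, `Cc1ccccc1-n1nncc1CN1C(=O)C2(C(C#N)=C(N)Oc3c(N)cc4nc5ccccc5nc4c32)c2ccccc21`, in a functional assay on HCT-116 cells (Homo sapiens) for antiproliferative activity, read by MTT assay, with a stated time of 48 h (a higher number here means a weaker inhibitor, a lower number a stronger inhibitor), gives > 50000 nM, which is a limit of the assay and not a number.
Compound 2, `N#CC1=C(N)Oc2c(N)cc3nc4ccccc4nc3c2C12C(=O)N(Cc1cnnn1-c1ccccc1Cl)c1ccccc12`, in this assay gives > 50000 nM, likewise a limit of the assay.
Compound 3, `N#CC1=C(N)Oc2c(N)cc3nc4ccccc4nc3c2C12C(=O)N(Cc1cnnn1-c1ccccc1Br)c1ccccc12`, in this assay gives 12400 nM.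

Going by the values given here, compound 3 therefore holds the only number among the three; the other two sit at the limit of > 50000 nM in this assay, at which 2 of the 3 values shown sit. Each of the three differs only in the group carried by the aromatic nitrogen of the five-membered ring with three nitrogens. From methyl to bromo, an at least 4.0-fold lower number from compound 1 to compound 3 (0.60 log units; beyond the scatter); from chloro to bromo, an at least 4.0-fold lower number from compound 2 to compound 3 (0.60 log units; beyond the scatter); between methyl and chloro, a step that the two limits leave unreadable from compound 1 to compound 2.

Compound 4, `CC(=O)Nc1ccc(-n2nncc2CN2C(=O)C3(C(C#N)=C(N)Oc4c(N)cc5nc6ccccc6nc5c43)c3ccccc32)cc1`, changes the same position again: 4-acetamidophenyl in place of 2-bromophenyl on an aromatic nitrogen. All three measured steps bear on this change, since they swap the group on that nitrogen, and they show that the bromo compound alone escapes the limit. Among the compounds with values here, no measured step carries an acetamido group, so its direction rests on weak ground. Because the bromo gave an at least 4.0-fold lower number from compound 2 to compound 3 (0.60 log units; beyond the scatter) and its loss is the most direct part of this change, the number for compound 4 is expected to rise again, roughly by a 2.8-fold higher number from compound 3 to compound 4 (0.45 log units; beyond the scatter). Compound 4 is estimated at 35000 nM, within a range from 8000 nM to 120000 nM.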

Compound 4, half-maximal inhibitory concentration: > 50000 nM
Compound 4 was reported as a limit; the forecaster's own chance of this, stated with the estimate: 50%; middle value at least 1.4-fold (0.15 log units) from the limit.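

Going by these compounds alone, the change from 2-bromophenyl to 4-acetamidophenyl on the aromatic nitrogen gives an at least 4.0-fold higher number from compound 3 to compound 4 (0.60 log units; beyond the scatter), the first measured step at this position in which the phenyl ring itself carries a group other than a single atom or methyl. In this assay, compound 4 gives > 50000 nM, which is a limit of the assay and not a number. Among the compounds shown, the number therefore remains confined to the 2-bromophenyl of compound 3, and the steps from compound 1 and from compound 2 to compound 4 cannot be read, since each runs between two limits: the limit of > 50000 nM in this assay, at which 3 of the 4 values shown sit.

Compound 4 removes the bromo group and brings in the acetamido group at a different place on the phenyl ring, and nothing shown separates these changes. Also open, going by these compounds, is how a 2-iodophenyl, a 4-bromophenyl or an unsubstituted phenyl would behave in this assay, and whether any of them would improve on compound 3 at 12400 nM.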